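The source may hold more compounds than are shown below. What is called first, only, known or untested is meant among the compounds shown, and "the series" means these compounds.

In an ADME assay on microsomes from liver (Homo sapiens) for metabolic stability, read by LC-MS, using NADPH, with stated times of 5 min and 30 min, tested at 1 uM (a higher number here means faster removal of the compound, a lower number slower removal), compound 2 `Cc1nc(CO)ccc1-c1cnc(NCc2c(F)ccc3c2CCO3)c2cn[nH]c(=O)c12` gives 11 mL.min-1.g-1 and stands within the scatter of the other two measured compounds: compound 1 `Fc1ccc2c(c1CNc1ncc(Oc3ccccc3)c3nncn13)CCO2` gives 18 mL.min-1.g-1 and compound 3 `CC1(C)CC(=O)N(c2cnc(NCc3c(F)ccc4c3CCO4)n3cnnc23)C1` gives 16 mL.min-1.g-1 on the same scale. Compound 4 `Cc1cc(-c2cnc(NCc3c(F)ccc4c3CCO4)c3cn[nH]c(=O)c23)n(C)n1` has 1,3-dimethyl-1H-pyrazol-5-yl in place of 6-(hydroxymethyl)-2-methylpyridin-3-yl on an aromatic carbon, so a five-membered aromatic ring replaces a six-membered one; the full count is 1,3-dimethyl-1H-pyrazol-5-yl in place of 6-(hydroxymethyl)-2-methylpyridin-3-yl on an aromatic carbon here. For the measured compounds named here, the only measured step available, a 1.1-fold lower number from compound 1 to compound 3 (0.05 log units; within the scatter), involves other groups on a different core and lies within the scatter. Going by the values given here, it therefore bears on this change only loosely, and no measured step tests this replacement directly. The expected 1.3-fold higher number from compound 2 to compound 4 (0.10 log units; within the scatter) stays within the scatter in this assay with no direction favoured. Compound 4 is estimated at 14 mL.min-1.g-1 with 7 mL.min-1.g-1 to 28 mL.min-1.g-1 as the expected range.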

Compound 4, intrinsic clearance in microsomes: 24 mL.min-1.g-1
Compound 4: middle estimate off by 1.7-fold (0.23 log units), on the low side, and the stated range covers the measured number.
By their numbers in this assay, from the lowest: compounds 2, 3, 1 and 4 (each within the scatter of the next, the first and the last beyond it).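

In this assay the exchange at this aromatic carbon gives a 2.2-fold higher number from compound 2 to compound 4 (0.34 log units; beyond the scatter) as a modest step, the first one in the series to pass the scatter, while a 1.1-fold lower number from compound 1 to compound 3 (0.05 log units; within the scatter) stayed inside it. On the shared core, then, the group at this position can shift intrinsic clearance, and here 1,3-dimethyl-1H-pyrazol-5-yl goes with faster removal than 6-(hydroxymethyl)-2-methylpyridin-3-yl. The exchange alters ring size, hetero atom count and the hydroxymethyl donor together, and nothing at hand gives a reason for the step.

Still open, from the compounds shown here alone, is whether the step follows the loss of the hydroxymethyl or the change of ring. A 2-methylpyridin-3-yl without hydroxymethyl, or a pyrazole carrying a hydroxymethyl or a carboxylic acid, would separate the two.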